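This account rests on a few compounds, and the source may have more. Where it says the series, first, only, none or still open, it means among the compounds named here.

Compound 1 `Oc1ccc(NC(=S)Nc2ccc3[nH]ccc3c2)cc1` gives 848000 nM
Compound 2 `OCc1ccc(NC(=S)Nc2ccc3[nH]ccc3c2)cc1` gives 1080000 nM
Compound 3 `O=C(c1ccccc1)c1ccc(NC(=S)Nc2ccc3[nH]ccc3c2)cc1` gives 20000 nM

In an ADME assay on CHO-K1 cells (Cricetulus griseus) for cytotoxicity, read by MTT assay, with a stated time of 24 h (a higher number here means that more compound is tolerated, a lower number that less compound is tolerated), compound 1 lies within the scatter of compound 2 and far above compound 3. Compound 4 `COC(=O)c1cc(NC(=S)Nc2ccc3[nH]ccc3c2)ccc1O` keeps the hydroxy group of compound 1 and carries methoxycarbonyl in place of hydrogen on an aromatic carbon, ortho to a hydroxy group (methoxycarbonyl in place of hydrogen on an aromatic carbon). For the measured compounds named here, no measured step makes this change, so the evidence is indirect. Hydroxymethyl in place of hydroxy gave a 1.3-fold higher number from compound 1 to compound 2 (0.11 log units; within the scatter) and benzoyl in place of hydroxy gave a 42-fold lower number from compound 1 to compound 3 (1.63 log units; beyond the scatter) as a large step. Methoxycarbonyl has no ring, so a smaller move toward lower numbers is expected, estimated as a 2.8-fold lower number from compound 1 to compound 4 (0.45 log units; beyond the scatter) here. Compound 4 is estimated at 300000 nM with an expected range of 70000 nM to 900000 nM in this assay.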

Compound 4, concentration lethal to 50% of the cells: 423000 nM
Compound 4: the middle estimate sits 1.4-fold (0.15 log units) below what was measured, within the range that was stated.
By their numbers in this assay, from the lowest: compound 3; then compounds 4, 1 and 2 (each within the scatter of the next, the first and the last beyond it).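

In this assay, placing methoxycarbonyl ortho to a hydroxy group gives a 2.0-fold lower number from compound 1 to compound 4 (0.30 log units; within the scatter), so this previously unsubstituted ring position accepts a group of 4 heavy atoms without a step beyond the scatter. Unlike the changes in compound 2 and compound 3, this one keeps the hydroxy group and adds to the ring. Nothing measured here explains the result. As far as these compounds go, whether a carboxylic acid or a longer ester at this position would also stay within the scatter of compound 1 remains open. So does whether methoxycarbonyl would give the same result without the neighbouring hydroxy group.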